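Removing an ethyl from a low-clearance compound

The compounds below may be only part of what the source reports. "The series", "measured", "known", "first", "only" and "open" are said of these compounds alone.

- compound 1 `CC1CN(c2cccnc2)C(=O)c2ccc(Cl)cc21` gives 6.6 mL/min/kg 
- compound 2 `CCC1c2cc(Cl)ccc2C(=O)N1c1cccnc1` gives 6.6 mL/min/kg 
- compound 3 `CCC(=O)N[C@@H]1CCCc2c1cncc2N1C(=O)c2ccc(Cl)cc2[C@@H]1CC` gives < 3.5 mL/min/kg (a limit)

All three results come from an ADME assay on microsomes from liver (Homo sapiens) for metabolic stability, read by LC-MS, using NADPH, with stated times of 10 min and 30 min (a lower number here means slower removal, a higher number faster removal of the compound), and describe how quickly each compound is removed. Compound 1 and compound 2 show the same number. Compound 3 is different in kind: its result of < 3.5 mL/min/kg is a limit of the assay and not a number.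

The next compound to be measured is compound 4 `CCC(=O)N[C@@H]1CCCc2c1cncc2N1Cc2cc(Cl)ccc2C1=O` and it differs from compound 3 in one place. The change, (hydrogen in place of ethyl on a saturated ring carbon), is hydrogen in place of ethyl on a saturated ring carbon. Among the compounds with values here, no measured pair shows this change alone, so the data give no direct size for it.

Compound 3 is the closest measured structure, so the expectation starts there. No change beyond the usual scatter is expected, and the estimated step of an at least 1.1-fold higher number from compound 3 to compound 4 (0.05 log units; that floor lies within the scatter) is correspondingly small. The upper end of the range leaves room for a result like that of compound 2 at 6.6 mL/min/kg in the same test. The estimate for compound 4 is 4 mL/min/kg within an expected range of 2.5 mL/min/kg to 8 mL/min/kg in this assay and the result may again be only a limit.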

Compound 4, clearance: < 3.5 mL/min/kg
Compound 4 gave a limit, no number; the forecaster's own chance of this, stated with the estimate: 45%; middle value at least 1.1-fold (0.05 log units) from the limit.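

In this assay compound 4 gives < 3.5 mL/min/kg, a limit of the assay and not a number. Compound 3 also carries a limit, so no step can be read from compound 3 to compound 4: the limit of < 3.5 mL/min/kg in this assay, at which 2 of the 4 values shown sit. The compounds shown leave open whether hydrogen in place of ethyl on a saturated ring carbon changes clearance at all, and in which direction.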